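Swapping a Nitrile for an Amine on a Kinase Inhibitor

The source may report more compounds than this note shows. Statements on the series, on what has been measured and on what is new or still open speak of the compounds shown alone.

Of the compounds shown here, three have been measured in an assay on isolated protein for inhibition of Rho-associated protein kinase 2 (Homo sapiens), read by scintillation counting, radiometric assay and 33P incorporation, with a stated time of 40 min, in the presence of a further agent that is not named here; on this read-out lower numbers stand for stronger inhibition and higher numbers for weaker inhibition. Compound 1 `COc1ccc(OCC(=O)Nc2cccc(NC(=O)c3ccc(N(C)C)cc3)c2)cc1F` gives 652 nM. Compound 2 `N#Cc1ccc(C(=O)Nc2cccc(NC(=O)COc3ccc4c(=O)ccoc4c3)c2)cc1` gives 15 nM. Compound 3 `O=C(COc1ccc2c(=O)ccoc2c1)Nc1cccc(NS(=O)(=O)c2ccc(OC(F)(F)F)cc2)c1` gives 1280 nM. Compound 2 therefore holds the lowest number of the three, and both of its gaps, to compound 1 and to compound 3, lie beyond the usual scatter of repeated measurements, so it is the strongest inhibitor in this set.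

The next compound keeps the whole of compound 2 except for one group. Compound 4 `Nc1ccc(C(=O)Nc2cccc(NC(=O)COc3ccc4c(=O)ccoc4c3)c2)cc1` differs from compound 2 as follows: amino in place of cyano on an aromatic carbon. No pair of measured compounds differing in just this way is available, so the size of this step cannot be read from the data shown; the other two compounds change several parts at once and offer no direct guide.

With nothing measured to anchor the step, a modest move toward weaker inhibition is expected in this assay, with the step from compound 2 to compound 4 estimated at a 3.3-fold higher number from compound 2 to compound 4 (0.52 log units; beyond the scatter). Compound 4 is thus expected to give about 50 nM, within a range from 15 nM to 200 nM.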

Compound 4, half-maximal inhibitory concentration: 83 nM
For compound 4 the middle estimate is 1.7-fold (0.22 log units) below the measured one, and the stated range covers the measured number.
By their numbers in this assay, from the lowest: compound 2; then compound 4; then compounds 1 and 3 (each within the scatter of the next).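

Among the compounds shown here, until now no two compounds differed in one place only, so the size of a single change could not be read; this pair shares everything except the group on one aromatic carbon, and going from cyano to amino gives a 5.5-fold higher number from compound 2 to compound 4 (0.74 log units; beyond the scatter). The step is modest but beyond the scatter, so the group at this position, para to a large group, does affect inhibition, with the 4-cyanophenyl form the stronger of the two, though the 4-aminophenyl form in compound 4 still gives 83 nM. Nothing measured in this set accounts for the difference between the two groups.

As far as these compounds go, how a plain hydrogen, a hydroxyl, a methoxy or a carboxylic acid would compare with the nitrile and the amine on this same carbon remains open, so one pair cannot yet show a trend across groups. Also open, from the compounds shown here alone, is whether swapping cyano for amino would give a step of similar size on a different core, or with the group moved to another carbon of the same ring.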